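Swapping the Bicyclic Amide Headgroup in Compound 3

The source may report more compounds than this note shows. Statements on the series, on what has been measured and on what is new or still open speak of the compounds shown alone.

Measured compounds:
- Compound 1 `O=C(NCc1ccc(S(=O)(=O)N2CCCCC2)cc1)c1cc2cnccc2s1` gives 150 nM in an assay for inhibition of Nicotinamide phosphoribosyltransferase (Homo sapiens), read by mass spectrometry, with stated times of 15 min and 30 min; on this read-out higher numbers stand for weaker inhibition and lower numbers for stronger inhibition
- Compound 2 `Cn1c(C(=O)NCc2ccc(S(=O)(=O)c3ccccc3)cc2)cc2ccncc21` gives 410 nM in this assay
- Compound 3 `O=C(NCc1ccc(S(=O)(=O)c2ccccc2)cc1)c1ccc2nncn2c1` gives 370 nM in this assay

Among these three, compound 3 has the second highest number: its value sits within the scatter of compound 2, while compound 1 lies beyond the scatter with a lower number. Compound 4 `O=C(NCc1ccc(S(=O)(=O)c2ccccc2)cc1)c1cnc2nccn2c1` differs from compound 3 only in the ring system carried on the carbonyl carbon: a group of 9 heavy atoms (6 carbon, 3 nitrogen; one five-membered aromatic ring with 2 hetero atoms, one six-membered aromatic ring with 2 hetero atoms) in place of a group of 9 heavy atoms (6 carbon, 3 nitrogen; one five-membered aromatic ring with 3 hetero atoms, one six-membered aromatic ring with 1 hetero atom), on a carbonyl carbon. Since the two groups share the same atoms and the rest of the molecule is unchanged, the step in this assay is expected to be small, with no direction beyond the scatter. Compound 4 is therefore expected to give about 400 nM, between 150 nM and 1100 nM, a step of a 1.1-fold higher number from compound 3 to compound 4 (0.03 log units; within the scatter).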

Compound 4, half-maximal inhibitory concentration: 2 nM
Compound 4: the middle estimate sits 200-fold (2.30 log units) above what was measured; measured number outside the range, below it.
By their numbers in this assay, from the lowest: compound 4; then compound 1; then compounds 3 and 2 (each within the scatter of the next).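

The two ring systems on the carbonyl carbon have the same atoms and the same hydrogen-bond donor and acceptor counts, yet exchanging one for the other gives a 190-fold lower number from compound 3 to compound 4 (2.27 log units; beyond the scatter) in this assay, a large change. At this position, the atoms present do not settle the result; how they are joined matters greatly. No measurement here explains the change.

On these data alone, whether adding a methyl group or an amine to the ring system of compound 4 keeps this low number remains open. So does whether this ring system gives a similar step on the core of compound 1.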